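Ethoxy for chloro on the anilide ring: an expectation

The source may report more compounds than this note shows. Statements on the series, on what has been measured and on what is new or still open speak of the compounds shown alone.

Compound 1, `O=C(Nc1ccccc1)Nn1c(-c2ccccc2)nc2ccccc2c1=O`, in a functional assay on the whole organism (strain albino) with Mus musculus as the target, at a dose of 100 mg/kg by the intraperitoneal route; a higher number here means more inhibition at the dose given (going by the name of the read-out), a lower number less inhibition: 56%
Compound 2, `O=C(Nc1ccc([N+](=O)[O-])cc1)Nn1c(-c2ccccc2)nc2ccccc2c1=O`: 42%
Compound 3, `O=C(Nc1ccc(Cl)cc1)Nn1c(-c2ccccc2)nc2ccccc2c1=O`: 55%

Compound 3 stands second highest of the three numbers. Its nearest value is that of compound 1, and the step of a number 1 percentage points lower from compound 1 to compound 3 (within the scatter) lies within the scatter, so no order between these two can be read. Compound 2 lies furthest, and the step of a number 13 percentage points higher from compound 2 to compound 3 (beyond the scatter) is beyond the scatter, though modest. The change to compound 4, `CCOc1ccc(NC(=O)Nn2c(-c3ccccc3)nc3ccccc3c2=O)cc1`, is ethoxy in place of chloro on an aromatic carbon. Within the data shown here, no measured step exchanges chloro for ethoxy, so none bears directly on it. What the measured steps show is that the same aromatic carbon carried hydrogen or chloro with no difference beyond the scatter (a number 1 percentage points lower from compound 1 to compound 3 (within the scatter)), while nitro gave a modest drop (a number 14 percentage points lower from compound 1 to compound 2 (beyond the scatter)). Ethoxy enters without precedent in this set, so only the spread of the three numbers guides the expectation. For compound 4 the expected step is a number 3 percentage points lower from compound 3 to compound 4 (within the scatter), judged to stay within the scatter. In this assay compound 4 is estimated at 52%, with a range from 38% to 66%.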

Compound 4, a percentage reported as inhibition, in the whole organism at one dose (the size of the read-out at that dose, not a potency): 53%
Compound 4: middle estimate off by 1 percentage points, on the low side; low and high end bracket the measured number.
By their numbers in this assay, from the lowest: compound 2; then compounds 4, 3 and 1 (each within the scatter of the next).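

In this assay, ethoxy, with its 3 heavy atoms and 1 hydrogen-bond acceptor, takes the place of chloro, with its 1 heavy atom, and the result is a number 2 percentage points lower from compound 3 to compound 4 (within the scatter); against the unsubstituted ring the result is likewise a number 3 percentage points lower from compound 1 to compound 4 (within the scatter), so this aromatic carbon now has three groups, hydrogen, chloro and ethoxy, whose numbers cannot be told apart, and the larger group brings no readable change. Nitro remains the one group set apart, since the comparison with ethoxy gives a number 11 percentage points higher from compound 2 to compound 4 (beyond the scatter), a modest step that adds a third group to those lying beyond the scatter from compound 2. The data offer no explanation of why nitro separates from the other three groups at this position.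

From the compounds shown here alone, whether an amine, a carboxylic acid or a longer chain such as butoxy at this aromatic carbon would stay level with hydrogen, chloro and ethoxy or fall toward nitro remains open. Also open, going by these compounds, is whether ethoxy would behave the same way on another carbon of this ring, and, as the read-out comes from one dose only, how these compounds compare in potency.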